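A few compounds are considered here, and "the series" means these few. Any claim that something is new, unique, unknown or untested is made for them only; others in the source may bear on it.

Measured so far:
compound 1 `CC(C)=CCC1Cc2c(OCCCNC(=O)c3ccco3)cc(=O)n(CCCO)c2CC1(C)C` — 2.1%
compound 2 `COc1ccccc1NC(=O)Oc1cc(=O)n(CCCO)c2c1CC(CC=C(C)C)C(C)(C)C2` — 71.1%

In a functional assay on PANC-1 cells (Homo sapiens) for inhibition, read by MTT assay, with a stated time of 24 h, tested at 10 uM (on this read-out higher numbers stand for more inhibition at the one concentration tested (going by the name of the read-out) and lower numbers for less inhibition), compound 2 gives 71.1%, the highest of the two numbers measured; compound 1 gives 2.1%, and the nearest measured neighbour of compound 2 is therefore compound 1. Among the measured compounds shown here, the only measured step, a number 69 percentage points higher from compound 1 to compound 2 (beyond the scatter), exchanges the entire group on the aromatic oxygen of the shared core and carries no information on a smaller exchange within an aryl ring.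

Compound 3 `CC(C)=CCC1Cc2c(OC(=O)Nc3ccccc3F)cc(=O)n(CCCO)c2CC1(C)C` differs from compound 2 by fluoro in place of methoxy on an aromatic carbon. For the measured compounds named here, no measured step bears on this change: no pair of measured compounds differs only in a substituent on the (2-methoxyphenyl)carbamoyl group. The expectation therefore rests on compound 2 alone, with 71.1% as the anchor, and no step beyond the scatter is expected in either direction. The step expected is a number 6.1 percentage points lower from compound 2 to compound 3 (within the scatter). Compound 3 is accordingly estimated at 65%, with a range from 40% to 85% to allow for the absence of any directly comparable step.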

Compound 3, a percentage reported as inhibition, at one concentration (the size of the read-out at that concentration, not a potency): 52.3%
Estimate against measurement, compound 3: 12.7 percentage points above, and the stated range covers the measured number.
By their numbers in this assay, from the lowest: compound 1; then compound 3; then compound 2.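

In this assay, the aryl ring of the carbamoyl group proves sensitive to a single small exchange: fluoro in place of methoxy on an aromatic carbon, ortho to a large group, gives a number 18.8 percentage points lower from compound 2 to compound 3 (beyond the scatter), a difference that the earlier exchange of the whole group on the oxygen could not reveal. The change does not remove the advantage of the carbamoyl type of group over the 3-(((furan-2-yl)carbonyl)amino)propyl group, as the exchange on the oxygen still gives a number 50.2 percentage points higher from compound 1 to compound 3 (beyond the scatter), so the higher numbers do not depend on the methoxy group alone. Nothing at hand accounts for the difference between methoxy and fluoro at this place.

The compounds shown leave open whether chloro, ethoxy, an amine or a carboxylic acid at this same place would read closer to fluoro, to methoxy or to neither. Also open, from the compounds shown here alone, is how much of the higher numbers belongs to the carbamoyl link and how much to the substituted aryl ring, a question that a plain phenyl or a benzyl group on that link would address.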